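Lengthening the Ester Chain Beyond Compound 2

This account rests on a few compounds, and the source may have more. Where it says the series, first, only, none or still open, it means among the compounds named here.

- compound 1 `C=C[C@@](C)(/C=C/c1ccc(OC(=O)CCC)cc1)CCC=C(C)C` gives 54%
- compound 2 `C=C[C@@](C)(/C=C/c1ccc(OC(=O)CCCCC)cc1)CCC=C(C)C` gives 19%

Both numbers come from a functional assay on IMR-32 cells (Homo sapiens) for inhibition, with a stated time of 48 h, tested at 50 uM (a higher number here means more inhibition of growth at the concentration tested, a lower number less inhibition of growth), and compound 2 stands lower of the two, at 19% and clearly beyond the scatter of compound 1. The next compound to be measured is compound 3 `C=C[C@@](C)(/C=C/c1ccc(OC(=O)CCCCCCC)cc1)CCC=C(C)C` which carries ethyl in place of hydrogen on a saturated chain carbon, five bonds along the chain from a carbonyl carbon.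

For the measured compounds named here, one measured step bears on this change. The same swap, made three bonds along the chain from the carbonyl carbon, gave a number 35 percentage points lower from compound 1 to compound 2 (beyond the scatter) (a large step). A single step does not establish a trend, but it points downward. A fall of that size is not possible again because compound 2 gives only 19% (little room remains above no inhibition at all). A smaller step in the same direction is therefore expected in this assay and it may not clear the scatter. The expected step is a number 9 percentage points lower from compound 2 to compound 3 (within the scatter) (an estimate). The estimate for compound 3 is 10% (expected range 0% to 26%).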

Compound 3, percent growth inhibition at one concentration: 51%
Compound 3: middle estimate off by 41 percentage points, on the low side; the whole stated range lies below it.
By their numbers in this assay, from the lowest: compound 2; then compounds 3 and 1 (each within the scatter of the next).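

In this assay, the ethyl swap does not push the number in one direction along this chain: five bonds from the carbonyl carbon it gave a number 32 percentage points higher from compound 2 to compound 3 (beyond the scatter), whereas three bonds from the carbonyl carbon it gave a number 35 percentage points lower from compound 1 to compound 2 (beyond the scatter). Taken as a single change, butyl in place of hydrogen three bonds along the chain from the carbonyl carbon gave a number 3 percentage points lower from compound 1 to compound 3 (within the scatter), so the two compounds at the ends of this short series cannot be told apart, and compound 2 alone stands apart from both, which rules out a steady fall with chain length across these three compounds. Nothing available here explains this dip and recovery, so the shape of the series stands as an observation without a known cause.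

The compounds shown leave open whether a longer chain than that of compound 3 would hold its number or lose it again. They also leave open how the number would respond to an amine or a carboxylic acid at the far end of the chain.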